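Swapping Ethyl for Methylsulfanyl on Compound 1

This account rests on a few compounds, and the source may have more. Where it says the series, first, only, none or still open, it means among the compounds named here.

Compound 1, `CCc1ccc(-c2nc3c(=O)n(C)c(=O)n(C)c3[nH]2)cc1`, stands lowest among the three measured compounds in an assay for binding affinity to adenosine receptor A1 (Bos taurus) (a higher number here means a weaker inhibitor, a lower number a stronger inhibitor), where compound 1 gives 0.8 nM. Compound 3, `CCn1c(=O)c2nc(-c3ccc(S(=O)(=O)NCCN(C)C)cc3)[nH]c2n(CC)c1=O`, is the nearest of the others: in this assay compound 3 gives 3.3 nM, a gap that lies beyond the usual scatter. Compound 2, `Cn1c(=O)c2nc(-c3cccc([N+](=O)[O-])c3)[nH]c2n(C)c1=O`, is the furthest: in this assay compound 2 gives 50 nM. For the measured compounds named here, no two of the measured compounds differ in only one place, so no measured step is available to set a scale for a single substitution.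

Compound 4, `CSc1ccc(-c2nc3c(=O)n(C)c(=O)n(C)c3[nH]2)cc1`, differs from compound 1 in one place: methylsulfanyl in place of ethyl on an aromatic carbon. The shared core and the ring that carries the group are untouched. The measured compounds give no direct evidence on an exchange of this kind, and the account therefore rests on the closeness of the two groups as described. A small step in this assay is expected, if any at all beyond the scatter, with a slight lean toward a higher number. The step from compound 1 to compound 4 is expected to be a 1.9-fold higher number from compound 1 to compound 4 (0.27 log units; within the scatter). Compound 4 is accordingly estimated at 1.5 nM in this assay, within a range from 0.5 nM to 5 nM.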

Compound 4, half-maximal inhibitory concentration: 2 nM
Estimate against measurement, compound 4: 1.3-fold (0.12 log units) below; the measured number falls inside the stated range.
By their numbers in this assay, from the lowest: compound 1; then compounds 4 and 3 (each within the scatter of the next); then compound 2.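

In this assay, the exchange of ethyl for methylsulfanyl on an aromatic carbon, para to a large group, gives the only measured single-place step among the compounds shown: a 2.5-fold higher number from compound 1 to compound 4 (0.40 log units; beyond the scatter), a modest step. This position therefore responds to the exchange, even though both groups have the same number of heavy atoms, neither carries a ring or a net charge, and the main visible difference in the computed comparison is that methylsulfanyl brings sulfur and a hydrogen-bond acceptor. No measured evidence explains the step, which stands here as an observation only.

The compounds shown leave open whether the size of this step is particular to methylsulfanyl or would also appear with other groups on the same aromatic carbon, such as methoxy, an amine, or a longer chain like propyl. They also leave open whether the same exchange would give a similar step on a core carrying the ethyl groups seen in compound 3, since this single pair cannot establish a wider pattern.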